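The compounds below may be only part of what the source reports. "The series", "measured", "known", "first", "only" and "open" are said of these compounds alone.

Measured compounds:
Compound 1 `Fc1ccc(-c2csc(N/N=C/c3ccc(-n4ccnc4)cc3)n2)cc1` gives 18.7% in an ADME assay on THP-1 cells (Homo sapiens) for cytotoxicity, read by MTT assay, tested at 50 ug/mL; on this read-out lower numbers stand for less inhibition and higher numbers for more inhibition at the one concentration tested (going by the name of the read-out).
Compound 2 `COc1ccc(-c2csc(N/N=C/c3ccc(-n4ccnc4)cc3)n2)cc1` gives 26.8%.
Compound 3 `O=[N+]([O-])c1ccc(-c2csc(N/N=C/c3ccc(-n4ccnc4)cc3)n2)cc1` gives 16.4%.

Compound 1 stands second highest of the three numbers; its nearest neighbour is compound 3, with a number 2.3 percentage points lower from compound 1 to compound 3 (within the scatter), and its furthest is compound 2, with a number 8.1 percentage points higher from compound 1 to compound 2 (within the scatter). The unmeasured compound 4 `Fc1ccc(-c2csc(N/N=C/c3ccc(-n4cncn4)cc3)n2)cc1` differs from compound 1 in one place: 1H-1,2,4-triazol-1-yl in place of 1H-imidazol-1-yl on an aromatic carbon. For the measured compounds named here, none of the measured steps touches this part of the molecule; all three vary the group on the other ring, and they were small, the largest being a number 10.4 percentage points lower from compound 2 to compound 3 (beyond the scatter). With nothing directly bearing on this change, a step of no size beyond the scatter is expected, so that compound 4 is estimated at 19% (range 8% to 32%), a step of a number 0.3 percentage points higher from compound 1 to compound 4 (within the scatter) expected from compound 1.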

Compound 4, a percentage reported as inhibition, at one concentration (the size of the read-out at that concentration, not a potency): 35.9%
Beside the measured number, compound 4's estimate is 16.9 percentage points below it; the whole stated range lies below it.
By their numbers in this assay, from the lowest: compounds 3, 1, 2 and 4 (each within the scatter of the next, the first and the last beyond it).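

In this assay, putting 1H-1,2,4-triazol-1-yl in place of 1H-imidazol-1-yl gives a number 17.2 percentage points higher from compound 1 to compound 4 (beyond the scatter) and so shows that this position, para to a large group, can move the read-out, which the earlier changes on the other ring could not reveal. The five-membered aromatic ring stays, and only its hetero atoms differ, so even a small edit here counts. No measurement at hand explains this step. As far as these compounds go, whether the same swap would act alike with the methoxy of compound 2 or the nitro of compound 3 remains open. So does how a morpholine or a carboxylic acid would read at this position.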